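The source may hold more compounds than are shown below. What is called first, only, known or untested is meant among the compounds shown, and "the series" means these compounds.

Measured so far:
- compound 1, `COc1ccc(OC)c(/C=C/C(=O)N/N=C/c2ccccc2)c1` — "not determined" (no result reported) in a functional assay on SR cells (Homo sapiens) for antiproliferative activity, read by sulforhodamine B assay, with a stated time of 48 h; a higher number here means a weaker inhibitor of growth, a lower number a stronger inhibitor of growth
- compound 2, `COc1ccc(OC)c(/C=C/c2nnc(Nc3ccc(Cl)cc3)o2)c1` — 48200 nM

Going by these compounds, compound 1 stands nowhere on the numbers: in this assay compound 1 gives "not determined" (no result reported), so its place is unknown. Among the compounds with values here, compound 2 is the only measured compound, and in this assay compound 2 gives 48200 nM, a weak inhibition of growth. Compound 3, `COc1ccc(OC)c(/C=C/C(=O)N/N=C/c2ccc(Cl)cc2)c1`, differs from compound 1 in one place: chloro in place of hydrogen on an aromatic carbon on a six-membered aromatic ring of carbon only, para to a large group. Within the data shown here, no step between measured compounds exists to show what such a change does here, so only a small step in this assay is expected, of no clear direction, and likely none beyond the usual scatter. Resting on compound 2 alone, compound 3 is estimated at 30000 nM, with a range from 5000 nM to 150000 nM.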

Compound 3, concentration for 50% growth inhibition: 39 nM
Estimate against measurement, compound 3: 770-fold (2.89 log units) above; the whole stated range lies above it.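

In this assay, within the data shown here, compound 1 gives "not determined" (no result reported) while compound 3 gives 39 nM and so no step between compound 1 and compound 3 can be read. The compounds shown leave open what chloro in place of hydrogen does to growth inhibition here. No supporting evidence bears on this result.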